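Working notes: from compound 3 to compound 4

The compounds below may be only part of what the source reports. "The series", "measured", "known", "first", "only" and "open" are said of these compounds alone.

Measured in a functional assay on A549 cells (Homo sapiens) for antiproliferative activity, read by MTT assay, with a stated time of 24 h; on this read-out higher numbers stand for weaker inhibition and lower numbers for stronger inhibition:
- compound 1 `Cc1cccc(NNC(=O)c2ccc(NS(=O)(=O)c3cnc(O)nc3O)cc2)c1`: > 20000 nM
- compound 2 `O=C(NNc1ccccc1Cl)c1ccc(NS(=O)(=O)c2cnc(O)nc2O)cc1`: 3340 nM
- compound 3 `O=C(NNc1cccc(Cl)c1)c1ccc(NS(=O)(=O)c2cnc(O)nc2O)cc1`: 7290 nM

Compound 1 stands at > 20000 nM, which is a limit of the assay and not a number. Compound 3, at 7290 nM, holds the higher of the two actual numbers, and the nearest value belongs to compound 2 at 3340 nM.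

The next compound is compound 4 `O=C(NNc1ccc(F)cc1)c1ccc(NS(=O)(=O)c2cnc(O)nc2O)cc1`, with 4-fluorophenyl in place of 3-chlorophenyl on an amine nitrogen. For the measured compounds named here, two measured steps bear on this change. Putting 3-chlorophenyl in place of 2-chlorophenyl gave a 2.2-fold higher number from compound 2 to compound 3 (0.34 log units; beyond the scatter), a modest step. Putting chloro in place of methyl gave an at least 2.7-fold lower number from compound 1 to compound 3 (0.43 log units; beyond the scatter), which is at least modest. Going by the values given here, no measured compound carries the 4-fluorophenyl group, and the direction of the step is therefore open. A step of modest size at most is expected in this assay, most likely none beyond the scatter, with some chance of a loss towards the limit seen for compound 1.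

The expected step is a 1.1-fold higher number from compound 3 to compound 4 (0.04 log units; within the scatter). For compound 4 the estimate is 8000 nM, with an expected range of 3000 nM to 20000 nM.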

Compound 4, half-maximal inhibitory concentration: > 20000 nM
Compound 4 was reported as a limit; the forecaster's own chance of this, stated with the estimate: 20%; middle value at least 2.5-fold (0.39 log units) away from the limit.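

In this assay compound 4 gives > 20000 nM, which is a limit of the assay and not a number. On the amine nitrogen, 4-fluorophenyl does not hold the activity of the chlorophenyl groups, even though the entering and leaving groups match in heavy-atom count and in hydrogen-bond donors and acceptors: the change gives an at least 2.7-fold higher number from compound 3 to compound 4 (0.43 log units; beyond the scatter) and an at least 5.9-fold higher number from compound 2 to compound 4 (0.77 log units; beyond the scatter), while the step between compound 1 and compound 4 cannot be read, as both are limits. This position is therefore less tolerant of aryl changes than the modest step between the two chlorophenyl compounds suggested, and only compound 2 and compound 3 give actual numbers, with the other two compounds at the same limit: the limit of > 20000 nM in this assay, at which 2 of the 4 values shown sit.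

Compound 4 changes both the halogen and its position on the ring at once, and the compounds shown do not separate these two changes. Also open, going by these compounds, is how a 4-chlorophenyl group, a 2-fluorophenyl group or an aminophenyl group on this nitrogen would read in this assay.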